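Replacing Cyano with Aminomethyl in Compound 2

This account rests on a few compounds, and the source may have more. Where it says the series, first, only, none or still open, it means among the compounds named here.

In a functional assay on MCF7 cells (Homo sapiens) for antiproliferative activity, read by MTT assay, with a stated time of 48 h (on this read-out higher numbers stand for weaker inhibition and lower numbers for stronger inhibition), compound 1 `CCn1c(C(=O)NCCN(C)C)ccc1C(CC)(CC)c1ccc(OCCC(O)(CC)CC)c(C)c1` gives 430 nM. Compound 2 `CCn1c(C(=O)NCC#N)ccc1C(CC)(CC)c1ccc(OCCC(O)(CC)CC)c(C)c1` gives > 50000 nM, which is a limit of the assay and not a number. For the measured compounds named here, the only measured step, with cyano in place of (dimethylamino)methyl, is large: an at least 110-fold higher number from compound 1 to compound 2 (2.06 log units; beyond the scatter). Compound 3 `CCn1c(C(=O)NCCN)ccc1C(CC)(CC)c1ccc(OCCC(O)(CC)CC)c(C)c1` differs from compound 2 by aminomethyl in place of cyano on a saturated chain carbon bound to an amide-type nitrogen, with aminomethyl in place of cyano on a saturated chain carbon bound to an amide-type nitrogen. Because compound 1 gives 430 nM with the closely similar (dimethylamino)methyl, a large step towards stronger inhibition is expected in this assay. The expected step is an at least 50-fold lower number from compound 2 to compound 3 (1.69 log units; beyond the scatter). Compound 3 is estimated at 1000 nM, with an expected range of 200 nM to 6000 nM.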

Compound 3, half-maximal inhibitory concentration: 670 nM
Compound 3: middle estimate off by 1.5-fold (0.17 log units), on the high side; the measured number falls inside the stated range.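

In this assay, aminomethyl in place of cyano on this chain carbon gives an at least 74-fold lower number from compound 2 to compound 3 (1.87 log units; beyond the scatter). For compound 2 the read-out is a limit of the assay and not a number: the limit of > 50000 nM in this assay, at which 1 of the 3 values shown sits. Amino in place of dimethylamino gives a 1.6-fold higher number from compound 1 to compound 3 (0.19 log units; within the scatter), so the two methyl groups on the nitrogen make no measurable difference here, and both amines stand well apart from the nitrile.

On these data alone, whether a hydroxyl group or a carboxylic acid at the chain end would keep this activity stays open. So does the effect of a longer chain carrying the amine.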